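A few compounds are considered here, and "the series" means these few. Any claim that something is new, unique, unknown or untested is made for them only; others in the source may bear on it.

Three compounds built on one shared core differ only in the group carried on an aromatic carbon. In an assay on isolated protein for inhibition of adenosine deaminase (Bos taurus), with a stated time of 5 min (a lower number here means a stronger inhibitor, a higher number a weaker inhibitor), compound 1 `COC(=O)c1cccc(CC[C@H]([C@H](C)O)n2cnc3c(N)ncnc32)c1` gives 2.2 nM, and compound 2 `C[C@H](O)[C@@H](CCc1cccc(-c2nccs2)c1)n1cnc2c(N)ncnc21` gives 2.6 nM. For the measured compounds named here, compound 3 `C[C@H](O)[C@@H](CCc1cccc(CO)c1)n1cnc2c(N)ncnc21` gives 4.6 nM, the highest of the three numbers, although only the step of a 2.1-fold higher number from compound 1 to compound 3 (0.32 log units; beyond the scatter) lies beyond the scatter, while a 1.8-fold higher number from compound 2 to compound 3 (0.25 log units; within the scatter) does not. Compound 4 `C[C@H](O)[C@@H](CCc1cccc(C(N)=O)c1)n1cnc2c(N)ncnc21` is compound 3 with a single change: carbamoyl in place of hydroxymethyl on an aromatic carbon. The two earlier swaps at this same carbon were both small, one of them within the scatter, so for compound 4 only a small step of a 1.5-fold lower number from compound 3 to compound 4 (0.19 log units; within the scatter) toward a somewhat lower number is expected. Compound 4 is estimated at 3 nM, within a range from 1.5 nM to 7 nM.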

Compound 4, inhibition constant: 2.9 nM
The estimate for compound 4 lay 1.0-fold (0.01 log units) above the measured number, within the range that was stated.
By their numbers in this assay, from the lowest: compounds 1, 2, 4 and 3 (each within the scatter of the next, the first and the last beyond it).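

Carbamoyl joins the other groups at this aromatic carbon without a step beyond the scatter in this assay: there is a 1.6-fold lower number from compound 3 to compound 4 (0.20 log units; within the scatter) and a 1.1-fold higher number from compound 2 to compound 4 (0.05 log units; within the scatter) as well as a 1.3-fold higher number from compound 1 to compound 4 (0.12 log units; within the scatter) here. The last step, amino in place of methoxy on a carbonyl carbon, shows that the amide and the ester cannot be told apart in this assay. Nothing measured here explains why these groups read so alike.

Going by these compounds, whether a carboxylic acid or an amine on this carbon would stay in the same range remains open. So does the effect of a longer chain there.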